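Replacing the 2-chlorophenyl group in a tetrazole series

The source may hold more compounds than are shown below. What is called first, only, known or untested is meant among the compounds shown, and "the series" means these compounds.

Compound 1 `CCCCCCCCc1ccc(OCC(=O)Cn2nnc(-c3ccccc3Cl)n2)cc1` gives 28% in an ADME assay on S9 fraction from liver (Rattus norvegicus) for metabolic stability, read by LC-MS, using NADPH, with a stated time of 30 min; a lower number here means that less of the compound is left, a higher number that more of the compound is left.
Compound 2 `CCCCCCCCc1ccc(OCC(=O)Cn2nnc(-c3cccs3)n2)cc1` gives 8% in this assay.
Compound 3 `CCCCCCCCc1ccc(OCC(=O)Cn2nnc(Cc3ccccc3)n2)cc1` gives only a limit of the assay, < 5% in this assay, which sits at the limit of < 5% in this assay, at which 1 of the 3 values shown sits.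

Compound 1 stands highest of the two numbers shown, with compound 2 nearest. Compound 4 `CCCCCCCCc1ccc(OCC(=O)Cn2nnc(CCC(=O)O)n2)cc1` differs from compound 1 by 2-carboxyethyl in place of 2-chlorophenyl on an aromatic carbon. The two measured changes at the same position both point the same way: a number 20 percentage points lower from compound 1 to compound 2 (beyond the scatter) and a number at least 23 percentage points lower from compound 1 to compound 3 (beyond the scatter). Neither of those groups is the one that enters here, so the size of the new step is uncertain, but a drop is expected for compound 4, about a number 14 percentage points lower from compound 1 to compound 4 (beyond the scatter). Compound 4 is therefore estimated at 14%, within a range from 5% to 40%.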

Compound 4, percent of the compound remaining: < 5%
Compound 4: no number, only a limit (the forecaster's own chance of this, stated with the estimate: 25%); middle value at least 9 percentage points from the limit.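

The step to 2-carboxyethyl, which brings no ring and a hydrogen-bond donor, gives a number at least 23 percentage points lower from compound 1 to compound 4 (beyond the scatter), so in this assay a group without a ring also falls short of 2-chlorophenyl. Against thiophen-2-yl the result is a number at least 3 percentage points lower from compound 2 to compound 4 (that floor lies within the scatter), which sets no order between those two groups. Compound 4 gives only a limit, and its step to compound 3 cannot be read: the limit of < 5% in this assay, at which 2 of the 4 values shown sit.

From the compounds shown here alone, whether any group at this position leaves more compound than 2-chlorophenyl remains open. An amine, a longer chain or a fluorophenyl might answer that.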